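A few compounds are considered here, and "the series" means these few. Any claim that something is new, unique, unknown or untested is made for them only; others in the source may bear on it.

Measured so far: compound 1 `CCCCCn1c(Cc2cc(OC)c(OC)c(OC)c2)nc2c(N)ncnc21` gives 61700 nM in a functional assay on MCF7 cells (Homo sapiens) for antiproliferative activity; on this read-out higher numbers stand for weaker inhibition and lower numbers for stronger inhibition; compound 2 `COc1cc(Cc2nc3c(N)ncnc3n2CC2CCC2)cc(OC)c1OC` gives 45700 nM in this assay.

Compound 2 stands alongside compound 1, the gap between them within the scatter. Within the data shown here, the only measured step, a 1.4-fold lower number from compound 1 to compound 2 (0.13 log units; within the scatter), is the one that bears on compound 3 `C=CCCn1c(Cc2cc(OC)c(OC)c(OC)c2)nc2c(N)ncnc21`, which differs from compound 2 by allyl in place of cyclobutyl on a saturated chain carbon bound to an aromatic nitrogen. Because that step a 1.4-fold lower number from compound 1 to compound 2 (0.13 log units; within the scatter) stayed within the scatter, no step beyond the scatter is expected for compound 3 in this assay. Compound 3 is therefore estimated at 50000 nM, with a range of 20000 nM to 120000 nM, an expected step of a 1.1-fold higher number from compound 2 to compound 3 (0.04 log units; within the scatter).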

Compound 3, half-maximal inhibitory concentration: 40700 nM
Estimate against measurement, compound 3: 1.2-fold (0.09 log units) above, within the range that was stated.
By their numbers in this assay, from the lowest: compounds 3, 2 and 1 (each within the scatter of the next).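

In this assay, the change to but-3-en-1-yl reads as a 1.1-fold lower number from compound 2 to compound 3 (0.05 log units; within the scatter), and the change from the saturated chain reads as a 1.5-fold lower number from compound 1 to compound 3 (0.18 log units; within the scatter). Among these compounds, a double bond outside aromatic rings therefore joins the cyclobutyl ring and the saturated chain as a third kind of group here, and no pair among the three separates beyond the scatter. Nothing available explains this sameness.

On these data alone, whether an amine, a carboxylic acid or a much longer chain at this place would shift the number beyond the scatter remains open. So does the effect of changes elsewhere on the shared core.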